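A few compounds are considered here, and "the series" means these few. Any claim that something is new, unique, unknown or untested is made for them only; others in the source may bear on it.

Compound 1, whose structure is `CC(C)=CCC[C@]1(C)/C=C/[C@@H](OC(=O)C=C(C)C)[C@](C)(O)/C=C/C(=O)/C(CN(C)C)=C\C1`, gives the lowest of the two numbers recorded so far in a functional assay on HL-60 cells (Homo sapiens) for antiproliferative activity, read by MTT assay, with a stated time of 48 h (a higher number here means a weaker inhibitor, a lower number a stronger inhibitor), reading 140 nM. Compound 2, with structure `CC(C)=CCC[C@]1(C)/C=C/[C@@H](OC(=O)C=C(C)C)[C@](C)(O)/C=C/C(=O)/C(C[Si](c2ccccc2)(c2ccccc2)C(C)(C)C)=C\C1`, gives 14400 nM in this assay, a number that lies far beyond the scatter above that of compound 1. Compound 3, whose structure is `CSC(=S)OC/C1=C/C[C@](C)(CCC=C(C)C)/C=C/[C@@H](OC(=O)C=C(C)C)[C@](C)(O)/C=C/C1=O`, has not yet been measured in this assay. It differs from compound 1 as follows: a group of 5 heavy atoms (2 carbon, 1 oxygen, 2 sulfur; no ring) in place of a group of 3 heavy atoms (2 carbon, 1 nitrogen; no ring), on a saturated chain carbon bound to a double-bonded ring carbon. Among the compounds with values here, no step between measured compounds of the same kind is available, so the expectation for compound 3 rests on compound 1 and compound 2 alone. Compound 2 shows that replacing the dimethylamino group of compound 1 with a larger group can raise the number sharply, so the step of a 10-fold higher number from compound 1 to compound 3 (1.00 log units; beyond the scatter) is expected to go toward weaker inhibition, beyond the scatter but smaller than the gap to compound 2. Compound 3 is therefore expected to give about 1400 nM in this assay, with a likely range from 300 nM to 8000 nM.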

Compound 3, half-maximal inhibitory concentration: 180 nM
For compound 3 the middle estimate is 7.8-fold (0.89 log units) above the measured one; measured number below the stated range.
By their numbers in this assay, from the lowest: compounds 1 and 3 (each within the scatter of the next); then compound 2.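

In this assay, the exchange at this position, on a saturated chain carbon bound to a double-bonded ring carbon, gives a 1.3-fold higher number from compound 1 to compound 3 (0.11 log units; within the scatter) and so shows that the nitrogen of dimethylamino is not needed to keep the number of compound 1. The group that enters has more heavy atoms than dimethylamino, yet compound 3 stays within the scatter of compound 1, so a larger group at this place does not by itself lead to the number of compound 2, which reads 14400 nM in this assay. Nothing shown here explains why the two groups read alike.

Going by these compounds, whether a hydroxyl, a morpholine ring or a simple methyl ether at this place would also stay close to compound 1 remains open.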